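Working notes: compound 4, hydrogen in place of fluoro

This account rests on a few compounds, and the source may have more. Where it says the series, first, only, none or still open, it means among the compounds named here.

Compound 1 `CCCn1c(=O)[nH]c2nc(-c3ccc(S(=O)(=O)N4CCN(Cc5cccc(C)c5)CC4)cc3)[nH]c2c1=O`: in an assay on CHO cells for displacement of a labelled ligand from adenosine receptor A3 (Homo sapiens), read by scintillation counting, with a stated time of 45 min, in the presence of a further agent that is not named here (a higher number here means a weaker inhibitor, a lower number a stronger inhibitor), compound 1 gives > 1000 nM, which is a limit of the assay and not a number.
Compound 2 `CCCn1c(=O)[nH]c2nc(-c3ccc(S(=O)(=O)N4CCN(Cc5cccc(Br)c5)CC4)cc3)[nH]c2c1=O`: in this assay compound 2 gives > 1000 nM, again a limit of the assay.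
Compound 3 `CCCn1c(=O)[nH]c2nc(-c3ccc(S(=O)(=O)N4CCN(c5ccccc5F)CC4)cc3)[nH]c2c1=O`: in this assay compound 3 gives > 1000 nM, also a limit of the assay.

Compound 3 therefore stands at a limit only, and the two other values shown stand at the same limit; all three sit at the limit of > 1000 nM in this assay, at which 3 of the 3 values shown sit. The steps between the measured pairs, a step that the two limits leave unreadable from compound 1 to compound 2, a step that the two limits leave unreadable from compound 1 to compound 3 and a step that the two limits leave unreadable from compound 2 to compound 3, cannot be read in size or direction, since both ends of each are limits. Of these, the steps from compound 1 and compound 2 to compound 3 change the group on the amine nitrogen in the ring, the same region as the next change, yet they give no readable size.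

Compound 4 `CCCn1c(=O)[nH]c2nc(-c3ccc(S(=O)(=O)N4CCN(c5ccccc5)CC4)cc3)[nH]c2c1=O` differs from compound 3 by hydrogen in place of fluoro on an aromatic carbon. Among the measured compounds shown here, no measured step bears readably on this change, so no step beyond the scatter is expected in this assay, and the step from compound 3 to compound 4 is expected to be a step that the limit leaves unreadable from compound 3 to compound 4. Compound 4 is expected to stay at the limit, with an estimate of 3000 nM and a range from 1000 nM to 10000 nM.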

Compound 4, inhibition constant: > 1000 nM
Compound 4 ended at the assay's limit (the forecaster's own chance of this, stated with the estimate: 85%); the middle value is on the limit's open side.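

No step can be read between compound 4 and compound 1, compound 2 or compound 3, since both ends of each step are limits of the assay and not numbers: the limit of > 1000 nM in this assay, at which 4 of the 4 values shown sit.

The compounds shown leave open which group on the amine nitrogen in the ring, if any, gives a readable value in this assay, and the size and direction of every step among these four compounds.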